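A few compounds are considered here, and "the series" means these few. Any claim that something is new, unique, unknown or untested is made for them only; others in the source may bear on it.

Working notes on the series, three compounds measured so far in a functional assay on the whole organism with Rattus norvegicus as the target, at a dose of 20 mg/kg by the intraperitoneal route; a higher number here means more inhibition at the dose given (going by the name of the read-out), a lower number less inhibition. Compound 1 `CCOc1ccccc1-c1nc(N)nc(N)n1` gives -5% in this assay, compound 2 `Nc1nc(N)nc(-c2cc(F)ccc2Cl)n1` gives 78%, and compound 3 `Nc1nc(N)nc(-c2cccc(F)c2)n1` gives 70%. Compound 3 thus stands close to compound 2, the two within the usual scatter of each other, and far above compound 1, a gap beyond the scatter. Among the compounds with values here, the one measured step between single-point neighbours, a number 8 percentage points lower from compound 2 to compound 3 (within the scatter), concerns hydrogen in place of chloro on an aromatic carbon and is within the scatter.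

Compound 4 `Nc1nc(N)nc(-c2cccc(C(F)(F)F)c2)n1` differs from compound 3 by trifluoromethyl in place of fluoro on an aromatic carbon. Within the data shown here, no measured step covers a change of this kind; the only step known, hydrogen in place of chloro, was small. The data therefore give no basis for expecting a move beyond the scatter in either direction, and the expected step is a number 5 percentage points lower from compound 3 to compound 4 (within the scatter). For compound 4 the estimate is 65%, with an expected range from 40% to 85%.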

Compound 4, a percentage reported as inhibition, in the whole organism at one dose (the size of the read-out at that dose, not a potency): 81%
Compound 4: middle estimate off by 16 percentage points, on the low side, and the stated range covers the measured number.
By their numbers in this assay, from the lowest: compound 1; then compounds 3, 2 and 4 (each within the scatter of the next, the first and the last beyond it).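

In this assay the change of trifluoromethyl in place of fluoro gives a number 11 percentage points higher from compound 3 to compound 4 (beyond the scatter), a modest step on an aromatic carbon, meta to a group of 8 heavy atoms. This place therefore takes a group of 4 heavy atoms instead of 1 with no loss of inhibition at the dose given, and with a gain beyond the scatter. The earlier step, hydrogen in place of chloro, stayed within the scatter and concerned a different change, so it could not show this. Nothing at hand offers an explanation for this step.

The compounds shown leave open how an amine, a carboxylic acid or a longer chain would fare at this same place. They also leave open whether the step would hold with chloro also on the ring.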